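Swapping the group on the amide carbonyl

A few compounds are considered here, and "the series" means these few. Any claim that something is new, unique, unknown or untested is made for them only; others in the source may bear on it.

Of the compounds shown here, three that share one core have been tested in an ADME assay on HepG2 2.2.15 cells (Homo sapiens) for cytotoxicity; a lower number here means that less compound is tolerated, a higher number that more compound is tolerated. Compound 1 `CC(C)(C)OC(=O)Nc1ncc(C(Oc2ccc3cc(Br)ccc3c2)c2ccc(Cl)cc2)s1` reaches only a limit of the assay; in this assay compound 1 gives > 50000 nM. Compound 2 `COC(=O)CCCCNc1ncc(C(Oc2ccc3cc(Br)ccc3c2)c2ccc(Cl)cc2)s1` is reported in this assay as "not toxic" (no number reported), without a number. Compound 3 `CCN(CC)C(=O)Nc1ncc(C(Oc2ccc3cc(Br)ccc3c2)c2ccc(Cl)cc2)s1` likewise stands without a number, reported in this assay as "not toxic" (no number reported), alongside the other two (the limit of > 50000 nM in this assay, at which 1 of the 3 values shown sits). Compound 4 `Cc1ccc(C(=O)Nc2ncc(C(Oc3ccc4cc(Br)ccc4c3)c3ccc(Cl)cc3)s2)cc1` differs from compound 3 by 4-methylphenyl in place of diethylamino on a carbonyl carbon. No measured step exists for this change, so the expectation rests on the three results shown, which all point to no toxicity; no shift beyond the scatter is expected. Compound 4 is therefore expected to give about 50000 nM in this assay, between 20000 nM and 100000 nM, most likely again as a limit rather than a number.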

Compound 4, half-maximal cytotoxic concentration: "not toxic" (no number reported)
Compound 4 has no reported number here; no gap can be computed for the estimate.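

Compound 3 and compound 4 are both reported in this assay as "not toxic" without a number, so no step can be read between them. The compounds shown leave open the concentration at which any of them would harm these cells, with only a limit on record: the limit of > 50000 nM in this assay, at which 1 of the 4 values shown sits.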